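A few compounds are considered here, and "the series" means these few. Any claim that something is new, unique, unknown or untested is made for them only; others in the source may bear on it.

Working notes on the series. Compound 1 `Cc1ccc(-c2ccc(COC3CN(C#N)C3)cc2)cc1` gives 0.46 nM in an assay on isolated protein for inhibition of N-acylethanolamine-hydrolyzing acid amidase (Homo sapiens), read by fluorescence, with a stated time of 90 min; a lower number here means a stronger inhibitor, a higher number a weaker inhibitor. Going by the values given here, compound 2 `N#CN1CC(OCc2ccc(Oc3ccccc3)cc2)C1` gives 1.1 nM in this assay; the one step known so far, a 2.4-fold higher number from compound 1 to compound 2 (0.38 log units; beyond the scatter), leaves compound 2 with the higher of the two numbers, compound 1 being its only and nearest neighbour. Compound 3 `COc1ccc(-c2cc(Oc3ccccc3)ccc2COC2CN(C#N)C2)cc1` is still awaited in this assay. It differs from compound 2 in a single place: 4-methoxyphenyl in place of hydrogen on an aromatic carbon, on an aromatic carbon of a six-membered aromatic ring of carbon only, ortho to the ((1-cyanoazetidin-3-yl)oxy)methyl group and meta to the phenoxy group. Among the compounds with values here, no measured step bears on this change; the only one known, a 2.4-fold higher number from compound 1 to compound 2 (0.38 log units; beyond the scatter), concerns a different substituent and leaves the ring that carries the linker untouched. With nothing to compare against, the expectation is held loosely: a modest rise in the number, a 2.7-fold higher number from compound 2 to compound 3 (0.44 log units; beyond the scatter), is expected, with the range left open in both directions. Compound 3 is therefore estimated at 3 nM, between 0.7 nM and 15 nM.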

Compound 3, half-maximal inhibitory concentration: 5.7 nM
Compound 3: the middle estimate sits 1.9-fold (0.28 log units) below what was measured; low and high end bracket the measured number.
By their numbers in this assay, from the lowest: compound 1; then compound 2; then compound 3.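

Placing 4-methoxyphenyl in place of hydrogen on the aromatic carbon ortho to the ((1-cyanoazetidin-3-yl)oxy)methyl group and meta to the phenoxy group gives the first reading at this position in this assay: a 5.2-fold higher number from compound 2 to compound 3 (0.71 log units; beyond the scatter). The ring that carries the linker, left untouched in the earlier step, thus responds to substitution at this carbon, yet the step is modest, and an entering group of 8 heavy atoms with one six-membered aromatic ring leaves compound 3 at 5.7 nM rather than ending inhibition. Nothing available explains why this substitution raises the number.

A single substituent cannot show whether the rise comes from the phenyl ring itself or from its methoxy group, and a methyl group, a fluorine atom, an unsubstituted phenyl or a phenyl bearing an amine at the same carbon would separate these readings. From the compounds shown here alone, it also remains open whether the same 4-methoxyphenyl change would give a similar step on the core of compound 1, where 4-methylphenyl stands in place of the phenoxy group.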